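Hydroxy(sulfo)methyl in place of formyl: cytotoxicity notes

The source may report more compounds than this note shows. Statements on the series, on what has been measured and on what is new or still open speak of the compounds shown alone.

In an ADME assay on HEK-293T cells (Homo sapiens) for cytotoxicity, with a stated time of 72 h (a higher number here means that more compound is tolerated, a lower number that less compound is tolerated), compound 1 `CCCC[C@H]1CC[C@H](OC(=O)N[C@@H](CC(C)C)C(=O)N[C@@H](C[C@@H]2CCNC2=O)C(O)S(=O)(=O)O)CC1` gives 58000 nM. Compound 2 `CCC[C@H]1CC[C@H](COC(=O)N[C@@H](CC(C)C)C(=O)N[C@@H](C[C@@H]2CCNC2=O)C(O)S(=O)(=O)O)CC1` gives 44000 nM; "not determined" (no result reported) (2 entries) in this assay, with the several entries of compound 2 being (the several entries of compound 2 in this assay, 44000 nM; "not determined" (no result reported) (2 entries)). Compound 3 `CCCC(OC(=O)N[C@@H](CC(C)C)C(=O)N[C@H](C=O)C[C@@H]1CCNC1=O)c1ccccc1` is reported in this assay only as a limit, > 100000 nM, and not as a number. Compound 3 thus sits at the tolerated edge of what has been recorded, as seen in the limit of > 100000 nM in this assay, at which 1 of the 3 values shown sits.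

Compound 4 `CCCC(OC(=O)N[C@@H](CC(C)C)C(=O)N[C@@H](C[C@@H]1CCNC1=O)C(O)S(=O)(=O)O)c1ccccc1` differs from compound 3 by hydroxy(sulfo)methyl in place of formyl on a saturated chain carbon bound to an amide-type nitrogen and a saturated chain carbon. Compounds 1 and 2 already carry this hydroxy(sulfo)methyl group and return numbers within this assay's measurable window, so for compound 4 a number is expected rather than a limit, though a limit remains possible. The step from compound 3 to compound 4 is expected to be small, an at least 1.4-fold lower number from compound 3 to compound 4 (0.15 log units; that floor lies within the scatter), in the direction of a somewhat less tolerated compound, and not clearly beyond the usual scatter given that compound 3 is a limit only. Compound 4 is therefore estimated at 70000 nM, with a range from 35000 nM to 150000 nM.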

Compound 4, half-maximal cytotoxic concentration: > 100000 nM
Compound 4 ended at the assay's limit (the forecaster's own chance of this, stated with the estimate: 40%); middle value at least 1.4-fold (0.15 log units) away from the limit.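

In this assay compound 4 gives > 100000 nM, a limit and not a number, so carrying hydroxy(sulfo)methyl does not by itself bring a compound of this series into the measurable range, and the top of the assay now holds more of the compounds shown: the limit of > 100000 nM in this assay, at which 2 of the 4 values shown sit.

Compound 3 and compound 4 both end at limits, so the step for hydroxy(sulfo)methyl in place of formyl cannot be read, and this position remains without a measured effect. With hydroxy(sulfo)methyl held constant, 1-phenylbutyl in place of 4-butylcyclohexyl on an oxygen next to a carbonyl group gives an at least 1.7-fold higher number from compound 1 to compound 4 (0.23 log units; that floor lies within the scatter), a step whose floor does not clear the scatter.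

On these data alone, how a carboxylic acid or a nitrile on this saturated chain carbon would read in this assay stays open. Also open, as far as these compounds go, is how far compound 4 lies from compound 3, since neither has a number.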